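The compounds below may be only part of what the source reports. "The series", "measured", "known", "first", "only" and "open" are said of these compounds alone.

- Compound 1 `CSc1nc(C)nc(SC)c1NC(=O)N(Cc1ccc(Oc2ccc(F)cc2)cc1)C1CCCCCC1`: 0.069 mg/kg
- Compound 2 `COc1cc(C)nc(OC)c1NC(=O)N(Cc1ccc(Oc2ccc(F)cc2)cc1)C1CCCCCC1`: 0.032 mg/kg

In a functional assay on the whole organism with Rattus norvegicus as the target (a higher number here means that more compound is needed for the effect, a lower number that less compound is needed), compound 1 has the higher of the two numbers, at 0.069 mg/kg. Compound 3 `COc1nc(C)cc(SC)c1NC(=O)N(Cc1ccc(Oc2ccc(F)cc2)cc1)C1CCCCCC1` has not been measured yet, and it differs from compound 1 in one place: a group of 11 heavy atoms (8 carbon, 1 nitrogen, 1 oxygen, 1 sulfur; one six-membered aromatic ring with 1 hetero atom) in place of a group of 11 heavy atoms (7 carbon, 2 nitrogen, 2 sulfur; one six-membered aromatic ring with 2 hetero atoms), on an amide-type nitrogen. Within the data shown here, the one measured step that bears on this is a 2.2-fold lower number from compound 1 to compound 2 (0.33 log units; beyond the scatter), which is modest and also brings in a group with one six-membered aromatic ring with 1 hetero atom. The group in compound 3 shares sulfur with compound 1 and oxygen with compound 2, so a smaller step in the same direction is expected, possibly within the scatter. The estimated step is a 1.5-fold lower number from compound 1 to compound 3 (0.19 log units; within the scatter). For compound 3 the expected value is 0.045 mg/kg, with an estimated range of 0.02 mg/kg to 0.1 mg/kg.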

Compound 3, dose for half-maximal effect: < 0.032 mg/kg
Compound 3: no number, only a limit; the forecaster's own chance of this, stated with the estimate: 2%; middle value at least 1.4-fold (0.14 log units) away from the limit.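

In this assay compound 3 gives only a limit, < 0.032 mg/kg, not an exact number. Even so, the group holding one sulfur and one oxygen on the amide-type nitrogen gives an at least 2.1-fold lower number from compound 1 to compound 3 (0.33 log units; beyond the scatter), so this gain does not require the removal of both sulfur atoms. Methylsulfanyl in place of methoxy gives a number no higher from compound 2 to compound 3 (the limit leaves the size open) and this step cannot be read for size.

From the compounds shown here alone, the true size of the gain stays open: the limit of < 0.032 mg/kg in this assay, at which 1 of the 3 values shown sits. Also open is how an amine or a longer chain, such as ethylsulfanyl, would behave in place of methylsulfanyl.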